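Compound 2 to compound 3: a larger carbon group

This account rests on a few compounds, and the source may have more. Where it says the series, first, only, none or still open, it means among the compounds named here.

Measured so far in a physicochemical assay for lipophilicity, at pH 7.4 (on this read-out lower numbers stand for lower lipophilicity and higher numbers for higher lipophilicity), for the series:
- Compound 1 `CCCCCCC/C=C/c1c(C)[nH]c2ccccc2c1=O` gives 4.26
- Compound 2 `COc1cc2[nH]c(C)c(C(C)C)c(=O)c2cc1Cl` gives 2.84

Compound 2 holds the lower of the two values, and its gap to compound 1 lies beyond the scatter. Compound 3 `C=C(CCCCC)c1c(C)[nH]c2cc(OC)c(Cl)cc2c1=O` differs from compound 2 by a group of 7 heavy atoms (7 carbon; no ring) in place of a group of 3 heavy atoms (3 carbon; no ring), on an aromatic carbon on an aromatic carbon. Among the measured compounds shown here, no single-place step between measured compounds is available, so the expectation rests on this change and on the two values. Compound 1 at 4.26 shows that higher values occur in the series. In this assay an upward step beyond the scatter is expected, estimated as a number 1.56 log units higher from compound 2 to compound 3 (beyond the scatter) in size. For compound 3 the estimated value is 4.4 with an expected range from 3.8 to 5 at the upper end.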

Compound 3, distribution coefficient: 3.58
For compound 3 the middle estimate is 0.82 log units above the measured one, and the stated range ends above it.
By their numbers in this assay, from the lowest: compound 2; then compound 3; then compound 1.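

In this assay, among the compounds shown here, replacing isopropyl on this aromatic carbon with the group of 7 heavy atoms gives a number 0.74 log units higher from compound 2 to compound 3 (beyond the scatter) as the first single-place step. A larger carbon group without a ring therefore moves the read-out upward at this position, though only modestly. No measurement on hand explains the size of this step.

Going by these compounds, whether a saturated chain of the same count would give a similar step stays open, since the entering group also holds a double bond. On these data alone, the effect of an amine or a carboxylic acid on this aromatic carbon in this assay also stays open.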